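The source may report more compounds than this note shows. Statements on the series, on what has been measured and on what is new or still open speak of the compounds shown alone.

In a toxicity assay on the whole organism with Rattus norvegicus as the target, at a dose of 200 mg/kg by the oral route (on this read-out lower numbers stand for a weaker effect and higher numbers for a stronger effect at the one dose given), three compounds have been measured:

compound 1, `COc1ccc(OCC2=NCCO2)cc1`: 10%
compound 2, `Brc1ccccc1OCC1=NCCO1`: 20%
compound 3, `Cc1cccc(OCC2=NCCO2)c1`: 20%

Compound 1 holds the lowest of the three numbers, yet neither of the other two is separated from it by more than the usual scatter of repeated measurements of this kind, so the three readings say much the same thing. Within the data shown here, no pair among them differs in only one place, and so no single structural step can be weighed.

Compound 4, `O=[N+]([O-])c1ccc(OCC2=NCCO2)cc1`, has not yet been measured in this assay. It differs from compound 1 in one way: nitro in place of methoxy on an aromatic carbon. Among the measured compounds shown here, no measured pair shows what such a change does on this read-out, so the expectation for compound 4 rests only on the common level of the three compounds, all of which sit in the same low band. A step of a number 10 percentage points higher from compound 1 to compound 4 (within the scatter) is expected, one that does not go beyond the scatter. For compound 4 the expected activity is 20% and the expected range runs from 5% to 40%.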

Compound 4, a percentage reported as activity, at one dose (the size of the read-out at that dose, not a potency): 15%
Estimate against measurement, compound 4: 5 percentage points above; the measured number falls inside the stated range.
By their numbers in this assay, from the lowest: compounds 1, 4, 2 and 3 (each within the scatter of the next).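

Nitro in place of methoxy on an aromatic carbon, para to a group of 7 heavy atoms, is the first change in one place that can be read in this assay, and it amounts to a step of a number 5 percentage points higher from compound 1 to compound 4 (within the scatter) on this read-out. At this position, then, two groups that differ in their heavy atoms and hydrogen-bond acceptors are not told apart, and the new compound stays in the band of the earlier three. No measured property is available that bears on this result.

On these data alone, whether an amine, a carboxylic acid or a longer chain in this same place would carry the read-out beyond the scatter stays open. So does whether nitro in place of methoxy would give a similar step elsewhere on the aromatic ring.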